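Chain extension from compound 1 to compound 3

The source may report more compounds than this note shows. Statements on the series, on what has been measured and on what is new or still open speak of the compounds shown alone.

- compound 1 `CCCCCCCCCCCCCCCC1(O)CC(=O)c2c(O)cc(O)cc2O1` gives 17500 nM
- compound 2 `CCCC/C=C\CCCCCCCCCC1(O)CC(=O)c2c(O)cc(OCOC)cc2O1` gives 43200 nM

In a functional assay on MCF7 cells (Homo sapiens) for antiproliferative activity, read by MTT assay (on this read-out higher numbers stand for weaker inhibition and lower numbers for stronger inhibition), compound 1 holds the lower of the two numbers, and compound 2 sits higher by more than the usual scatter. Compound 3 `CCCCCCCCCCCCCCCCCCCC1(O)CC(=O)c2c(O)cc(O)cc2O1` is still unmeasured and differs from compound 1 by butyl in place of hydrogen on a saturated chain carbon, ten or more bonds along the chain from a saturated ring carbon. Going by the values given here, no measured pair isolates a change of this kind, so only a small rise in this assay is expected, probably none beyond the scatter. The expected change is a 1.4-fold higher number from compound 1 to compound 3 (0.14 log units; within the scatter) and the number remains uncertain. For compound 3 the estimated value is 24000 nM with 10000 nM to 60000 nM as its expected range.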

Compound 3, half-maximal inhibitory concentration: > 67200 nM
Compound 3 gave a limit, no number (the forecaster's own chance of this, stated with the estimate: 15%); middle value at least 2.8-fold (0.44 log units) from the limit.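

In this assay, going by these compounds alone, butyl in place of hydrogen on a saturated chain carbon, ten or more bonds along the chain from a saturated ring carbon, is the first change that can be read alone, and it gives an at least 3.8-fold higher number from compound 1 to compound 3 (0.58 log units; beyond the scatter). This position on the chain of compound 1 therefore does not take the added butyl without a loss of inhibition beyond the scatter. Compound 3 stands as a limit, not a number: the limit of > 67200 nM in this assay, at which 1 of the 3 values shown sits.

Going by these compounds, the true size of the loss remains open. Also open, on these data alone, is whether a shorter chain, or an amine or carboxylic acid at this position, would keep or lower the number of compound 1.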